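The compounds below may be only part of what the source reports. "The series", "measured", "known", "first", "only" and "open" are said of these compounds alone.

Compound 1 `COc1cc2c(cc1C)NC(=O)/C2=C/c1c(Cl)n(C)c2cc(C)c(OC)cc12` and compound 2 `COc1cc2c(cc1C)N(C)C(=O)/C2=C/c1c(Cl)n(C)c2cc(C)c(OC)cc12` share one core. In a functional assay on cells (Cancer cell lines, Homo sapiens) for inhibition, with a stated time of 48 h (on this read-out lower numbers stand for stronger inhibition of growth and higher numbers for weaker inhibition of growth), compound 1 gives 22900 nM, and compound 2 gives 20400 nM. Within the data shown here, the one change between them is methyl in place of hydrogen on an amide-type nitrogen in a ring, and it made a 1.1-fold lower number from compound 1 to compound 2 (0.05 log units; within the scatter). Compound 3 `CN(C)c1ccc2[nH]c(Cl)c(/C=C3/C(=O)Nc4ccc(O)cc43)c2c1` rests on a different core; how that core differs from the core of compound 1 is not broken down here. In this assay compound 3 gives 3890 nM, the lowest of the three numbers, its gaps to compound 2 and compound 1 both lying beyond the scatter. Compound 4 `CN(C)c1ccc2[nH]c(Cl)c(/C=C3/C(=O)N(C)c4ccc(O)cc43)c2c1` has not been measured. It differs from compound 3 by methyl in place of hydrogen on an amide-type nitrogen in a ring, the same change at the same place as between compound 1 and compound 2. Because that earlier step was a 1.1-fold lower number from compound 1 to compound 2 (0.05 log units; within the scatter), a step of about the same small size is expected now, a 1.1-fold lower number from compound 3 to compound 4 (0.03 log units; within the scatter). Compound 4 is therefore estimated at 3600 nM in this assay, most likely between 1500 nM and 9000 nM.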

Compound 4, concentration for 50% growth inhibition: 4900 nM
Compound 4: middle estimate off by 1.4-fold (0.13 log units), on the low side; low and high end bracket the measured number.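

In this assay methyl in place of hydrogen on the amide-type nitrogen gave a 1.3-fold higher number from compound 3 to compound 4 (0.10 log units; within the scatter) and so, as on the core of compound 1, made only a small step. The two steps agree: the same change on two cores in this assay, a 1.1-fold lower number (0.05 log units; within the scatter) from compound 1 to compound 2 and a 1.3-fold higher number (0.10 log units; within the scatter) from compound 3 to compound 4, 1.4-fold (0.15 log units) apart, within the scatter of two such steps. This shows that the change carried over between these two cores in this one assay, with little effect on either, but two pairs make no general rule and say nothing about other cores or other assays.

The compounds shown leave open what a larger group on that nitrogen would do, such as a longer chain or a chain ending in an amine.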